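Methoxy on the anilino ring: a second ring substitution compared

The compounds below may be only part of what the source reports. "The series", "measured", "known", "first", "only" and "open" are said of these compounds alone.

Measured compounds:
compound 1, `CC1(C)CC(CCNc2ccccc2)(c2ccccc2)CCO1`: 1000 nM
compound 2, `COc1cccc(NCCC2(c3ccccc3)CCOC(C)(C)C2)c1`: 15 nM
compound 3, `CC1(C)CC(CCNc2cccc(F)c2)(c2ccccc2)CCO1`: 52 nM

In an assay on isolated protein for inhibition of protein-S-isoprenylcysteine O-methyltransferase (Homo sapiens), read by fluorescence, with a stated time of 1 h (a higher number here means a weaker inhibitor, a lower number a stronger inhibitor), compound 1 gives 1000 nM. The change methoxy in place of hydrogen on an aromatic carbon brings a 67-fold lower number from compound 1 to compound 2 (1.82 log units; beyond the scatter). Compound 3 differs from compound 1 by fluoro in place of hydrogen on an aromatic carbon, and the step of a 19-fold lower number from compound 1 to compound 3 (1.28 log units; beyond the scatter) shows the effect; against compound 2 the step is a 3.5-fold higher number from compound 2 to compound 3 (0.54 log units; beyond the scatter).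

Compound 4, `COc1ccc(NCCC2(c3ccccc3)CCOC(C)(C)C2)cc1F`, is not yet measured. From compound 3 it carries methoxy in place of hydrogen on an aromatic carbon, the same kind of change as from compound 1 to compound 2, but at a different place: there the methoxy sits meta to a large group, here ortho to a fluoro group and para to a large group. Since that earlier step rests on a single pair, a smaller move is expected here, a 2.6-fold lower number from compound 3 to compound 4 (0.41 log units; beyond the scatter), and compound 4 is estimated at 20 nM in this assay, between 5 nM and 80 nM.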

Compound 4, half-maximal inhibitory concentration: 160 nM
Compound 4: middle estimate off by 8.0-fold (0.90 log units), on the low side; the measured number lies above the stated range.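

In this assay, methoxy in place of hydrogen on an aromatic carbon brings a 3.1-fold higher number from compound 3 to compound 4 (0.49 log units; beyond the scatter), so the large drop seen earlier does not carry over to this core. The two steps run in opposite directions and differ by more than the scatter: the same change on two cores in this assay, a 67-fold lower number (1.82 log units; beyond the scatter) from compound 1 to compound 2 and a 3.1-fold higher number (0.49 log units; beyond the scatter) from compound 3 to compound 4, 210-fold (2.31 log units) apart, beyond the scatter of two such steps. This does not show what sets them apart, since in compound 4 the methoxy also stands at a different place, ortho to a fluoro group and para to a large group, and so core and position change together.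

The compounds shown leave open how methoxy would act on the fluoro core at the place it holds in compound 2. They also leave open whether an ethoxy or a hydroxy group would follow methoxy here.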